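Alkoxy position change on the pendant phenyl ring

A few compounds are considered here, and "the series" means these few. Any claim that something is new, unique, unknown or untested is made for them only; others in the source may bear on it.

Measured so far:
compound 1 `C=C(Br)C(=O)Nc1cccc(-c2cn3nc(-c4ccccc4)sc3n2)c1`, 1400 nM
compound 2 `C=C(Br)C(=O)Nc1cccc(-c2cn3nc(-c4ccc(OCC)cc4)sc3n2)c1`, 1100 nM

In a functional assay on HeLa cells (Homo sapiens) for inhibition, read by cell counting, with a stated time of 4 days (a lower number here means a stronger inhibitor, a higher number a weaker inhibitor), compound 2 carries the lower of the two numbers shown, but the step of a 1.3-fold lower number from compound 1 to compound 2 (0.10 log units; within the scatter) is within the scatter, so the two compounds are not separated by this assay. Going by the values given here, the only structural step measured, ethoxy in place of hydrogen on an aromatic carbon, therefore gave no change beyond the scatter.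

Compound 3 `C=C(Br)C(=O)Nc1cccc(-c2cn3nc(-c4cccc(OC)c4)sc3n2)c1` is the next member. Relative to compound 2 the change is 3-methoxyphenyl in place of 4-ethoxyphenyl on an aromatic carbon. Among the compounds with values here, no measured step covers an alkoxy group at this other ring position, nor the shorter chain; the one step that bears on the question, from compound 1 to compound 2, only shows that the 4-ethoxyphenyl and the unsubstituted phenyl behave alike. On that basis the expected step of a 1.2-fold higher number from compound 2 to compound 3 (0.07 log units; within the scatter) is none beyond the scatter, with a wide range to cover the untested position. Compound 3 is expected to give 1300 nM, within 500 nM to 3500 nM.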

Compound 3, half-maximal inhibitory concentration: 1100 nM
Compound 3: middle estimate off by 1.2-fold (0.07 log units), on the high side; the range from low to high includes it.
By their numbers in this assay, from the lowest: compounds 2, 3 and 1 (each within the scatter of the next).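

In this assay, the swap of 4-ethoxyphenyl for 3-methoxyphenyl gives no change at the digits printed from compound 2 to compound 3 (within the scatter), so changing ring position and chain together does not separate the two compounds. The step of a 1.3-fold lower number from compound 1 to compound 3 (0.10 log units; within the scatter) extends the earlier reading for the 4-ethoxyphenyl group: on the shared core, the 3-methoxyphenyl group is not separated from the unsubstituted phenyl either, and the three aryl groups at this carbon, next to the ring nitrogen and next to the ring sulfur, read alike in this assay. No evidence is available that could account for this flat reading.

With ring position and chain changed in one step, the compounds shown cannot assign any contribution to either change alone, and a methoxy group placed as in 4-ethoxyphenyl or an ethoxy group placed as in 3-methoxyphenyl would separate the two. Also open, on these data alone, is whether a longer chain such as butoxy, an amine such as dimethylamino or a carboxylic acid on this phenyl ring would give a step beyond the scatter.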